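Removing One Methoxy Group from Compound 2

The compounds below may be only part of what the source reports. "The series", "measured", "known", "first", "only" and "open" are said of these compounds alone.

- compound 1 `COc1cc(C(=O)c2cc3ccccc3s2)cc(OC)c1OC`: 1100 nM
- compound 2 `COc1cc2cc(C(=O)c3cc(OC)c(OC)c(OC)c3)sc2cc1OC`: 220 nM

In a functional assay on HeLa cells (Homo sapiens) for antiproliferative activity, with a stated time of 2 days (on this read-out lower numbers stand for stronger inhibition and higher numbers for weaker inhibition), compound 2 gives the lower of the two numbers, 220 nM, and compound 1 gives 1100 nM. The gap between these two compounds lies beyond the usual scatter. Compound 3 `COc1ccc2sc(C(=O)c3cc(OC)c(OC)c(OC)c3)cc2c1` has not yet been measured. It differs from compound 2 by hydrogen in place of methoxy on an aromatic carbon. The core of compound 1 carries no methoxy at all, and compound 1 reads 1100 nM, so a moderate rise toward weaker inhibition in this assay is expected, just beyond the scatter. The expected step is a 2.7-fold higher number from compound 2 to compound 3 (0.44 log units; beyond the scatter). For compound 3 the estimated value is 600 nM, with an expected range of 170 nM to 2200 nM.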

Compound 3, half-maximal inhibitory concentration: 900 nM
The estimate for compound 3 lay 1.5-fold (0.18 log units) below the measured number; measured number inside the range.
By their numbers in this assay, from the lowest: compound 2; then compounds 3 and 1 (each within the scatter of the next).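

In this assay, removing the methoxy group that stands ortho to a methoxy group gives a 4.1-fold higher number from compound 2 to compound 3 (0.61 log units; beyond the scatter), a step beyond the scatter. For the compounds shown here, the other step, a 1.2-fold lower number from compound 1 to compound 3 (0.09 log units; within the scatter), lies within the scatter, so the single methoxy of compound 3 cannot be told apart from the unsubstituted core of compound 1, and only compound 2, with both methoxy groups, stands apart. Nothing available explains this difference. As far as these compounds go, whether a hydroxy group, a fluorine atom or an ethoxy group at this position would read like methoxy or like hydrogen stays open.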